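A few compounds are considered here, and "the series" means these few. Any claim that something is new, unique, unknown or untested is made for them only; others in the source may bear on it.

Compound 1 `Cc1nc2ccccc2c(=O)n1/N=C/c1ccc(Oc2ccc(Br)cc2)cc1`: in a physicochemical assay for lipophilicity, in phosphate buffer, measured as octanol-water partition (on this read-out higher numbers stand for higher lipophilicity and lower numbers for lower lipophilicity), compound 1 gives 4.64
Compound 2 `O=c1c2ccccc2nc(-c2ccccc2)n1/N=C/c1ccc(Oc2ccc(Br)cc2)cc1`: in this assay compound 2 gives 6.39

Going by the values given here, of the two measured compounds, compound 2 stands highest in this assay; the one measured step runs toward it, a number 1.75 log units higher from compound 1 to compound 2 (beyond the scatter), a change that swapped one group on the shared core for a much larger one.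

Compound 3 `O=c1c2ccccc2nc(-c2ccccc2)n1/N=C/c1ccc(Oc2ccc(Cl)cc2)cc1` has not yet been measured. It differs from compound 2 in a single place: chloro in place of bromo on an aromatic carbon. The change sits at the far end of the molecule, on the ring that carries the halogen, para to a large group.

Among the compounds with values here, nothing measured so far speaks directly to this swap. Within the data shown here, the only recorded step, a number 1.75 log units higher from compound 1 to compound 2 (beyond the scatter), concerns a different part of the shared core and a far bigger exchange, so it gives no guide to the size of a halogen-for-halogen change. With one atom replaced by another of the same kind and nothing else altered, the step in this assay is expected to be small, at most a slight fall, and quite possibly within the usual scatter. On that basis compound 3 is estimated at 6.2, with a range from 5.7 to 6.7. The expected step is a number 0.19 log units lower from compound 2 to compound 3 (within the scatter).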

Compound 3, partition coefficient: 6.38
Compound 3: middle estimate off by 0.18 log units, on the low side, within the range that was stated.
By their numbers in this assay, from the lowest: compound 1; then compounds 3 and 2 (each within the scatter of the next).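

Exchanging the halogen on the aromatic ring at the far end of the molecule, para to a large group, gives a number 0.01 log units lower from compound 2 to compound 3 (within the scatter) in this assay, so on this read-out compound 2 and compound 3 cannot be told apart. Going by these compounds alone, this is the first reading at this position, since the earlier step, a number 1.75 log units higher from compound 1 to compound 2 (beyond the scatter), came from a phenyl-for-methyl exchange elsewhere on the shared core and said nothing about the halogen-bearing ring. No separate measurement is available to explain the reading for this pair.

The compounds shown leave open how this position would read with a group of a different kind, such as an amine, a carboxylic acid or a longer chain. Bromo and chloro are the only two groups seen there so far, and both are single halogen atoms. From the compounds shown here alone, it also remains open whether the same chloro-for-bromo exchange would read the same way on the core of compound 1, which carries methyl where compound 2 and compound 3 carry phenyl.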